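The source may report more compounds than this note shows. Statements on the series, on what has been measured and on what is new or still open speak of the compounds shown alone.

Notes on the series. Four compounds are in view; the difference between the core of compound 1 `COc1cc(/C=N/NC(=O)CCCc2nc3ccccc3c(=O)[nH]2)ccc1O` and the core of compound 3 `COc1cc(/C=N/NC(=O)CCc2nc3ccccc3c(=O)[nH]2)ccc1O` is not broken down here. In a physicochemical assay, read by spectrophotometry, with a stated time of 30 min (on this read-out higher numbers stand for weaker inhibition and lower numbers for stronger inhibition), compound 1 gives 236000000 nM. Compound 2 `COc1cc(/C=N/NC(=O)CCCc2nc3ccccc3c(=O)[nH]2)cc(OC)c1O` differs from compound 1 by methoxy in place of hydrogen on an aromatic carbon, and in this assay compound 2 gives 97000000 nM, a step of a 2.4-fold lower number from compound 1 to compound 2 (0.39 log units; beyond the scatter). In this assay compound 3 gives 204000000 nM; this value and that of compound 1 lie within the scatter of each other, while the values of compound 3 and compound 2 are separated by more than the scatter.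

Compound 4 `COc1cc(/C=N/NC(=O)CCc2nc3ccccc3c(=O)[nH]2)cc(OC)c1O` has not yet been measured. Among the compounds with values here, it differs from compound 3 by methoxy in place of hydrogen on an aromatic carbon, which is the same change as the one from compound 1 to compound 2: the two descriptions of the place agree word for word. Among the compounds shown this change occurs two times, once with both partners measured. The expectation for compound 4 therefore rests on a single measured pair and is loose. Within the data shown here, compound 4 is expected to give about 85000000 nM in this assay, a step of roughly a 2.4-fold lower number from compound 3 to compound 4 (0.38 log units; beyond the scatter), because the step of a 2.4-fold lower number from compound 1 to compound 2 (0.39 log units; beyond the scatter) is the only precedent for this change. The expected range for compound 4 is estimated to run from 45000000 nM to 200000000 nM.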

Compound 4, half-maximal inhibitory concentration: 126000000 nM
Compound 4: the middle estimate sits 1.5-fold (0.17 log units) below what was measured; the measured number falls inside the stated range.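

In this assay, methoxy in place of hydrogen on the core of compound 3 gives a 1.6-fold lower number from compound 3 to compound 4 (0.21 log units; within the scatter), so the step seen on the core of compound 1, a 2.4-fold lower number from compound 1 to compound 2 (0.39 log units; beyond the scatter), does not recur beyond the scatter on the second core. Within the data shown here, with a single pair on each core, this does not show that the change is without effect on the core of compound 3, nor that the two cores truly respond differently; it shows only that a step of this kind cannot yet be relied on to carry from one core to another. Nothing at hand bears on why the two pairs read as they do.

The compounds shown leave open whether other groups in the same place on the aromatic ring, such as an ethoxy, an amine or a carboxylic acid, would give steps that hold across both cores. They also leave open whether the methoxy step would read the same on a core with a longer chain, and further pairs on either core would be needed to settle how far this change carries.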